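The compounds below may be only part of what the source reports. "The series", "measured", "known", "first", "only" and "open" are said of these compounds alone.

Compound 1 `O=C(Nc1ccc(Oc2ccnc3[nH]ccc23)cc1)c1cc2cccnc2n(-c2ccccc2)c1=O` gives 1580 nM in a functional assay on U-87MG ATCC cells for antiproliferative activity against U-87 MG (Homo sapiens), read by MTT assay, with a stated time of 72 h (on this read-out higher numbers stand for weaker inhibition and lower numbers for stronger inhibition), compound 2 `O=C(Nc1ccc(Oc2ccnc3[nH]ccc23)cc1)c1cc2cccnc2n(-c2ccc(Cl)cc2)c1=O` gives 3370 nM, and for compound 3 `O=C(Nc1ccc(Oc2ccnc3[nH]ccc23)cc1)c1cc2cccnc2n(-c2ccc(Br)cc2)c1=O` the entry reads "not determined" (no result reported), so no result is reported for it.

In this assay compound 2 gives 3370 nM, the highest of the two numbers available, while compound 1 gives 1580 nM. Among the compounds with values here, the only measured step is a 2.1-fold higher number from compound 1 to compound 2 (0.33 log units; beyond the scatter), a modest shift at the aromatic carbon para to a large group. Compound 4 `COc1ccc(-n2c(=O)c(C(=O)Nc3ccc(Oc4ccnc5[nH]ccc45)cc3)cc3cccnc32)cc1` differs from compound 2 by methoxy in place of chloro on an aromatic carbon. Within the data shown here, no measured step exchanges chloro for methoxy, so the expectation rests only on the single step observed at this position, which was modest. Compound 4 is therefore expected to show a step of a 1.3-fold lower number from compound 2 to compound 4 (0.13 log units; within the scatter), small and of uncertain direction. The estimate for compound 4 is 2500 nM, within a range from 800 nM to 8000 nM.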

Compound 4, half-maximal inhibitory concentration: 2350 nM
Compound 4: the middle estimate sits 1.1-fold (0.03 log units) above what was measured; low and high end bracket the measured number.
By their numbers in this assay, from the lowest: compounds 1, 4 and 2 (each within the scatter of the next, the first and the last beyond it).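

In this assay methoxy, with its one hydrogen-bond acceptor, does not set compound 4 apart from either the chloro or the hydrogen compound at this place (a 1.4-fold lower number from compound 2 to compound 4 (0.16 log units; within the scatter); a 1.5-fold higher number from compound 1 to compound 4 (0.17 log units; within the scatter)). Among these compounds, only the change from hydrogen to chloro lies beyond the scatter, so a larger group at this place need not give a step that can be told from the scatter. No measured evidence bears on why these steps have this size.

From the compounds shown here alone, whether an amine or a carboxylic acid at this place would give a step beyond the scatter remains open. So does whether any group here would give a lower number than hydrogen.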